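Hydroxy for nitro on the benzylidene ring of compound 3

The source may hold more compounds than are shown below. What is called first, only, known or untested is meant among the compounds shown, and "the series" means these compounds.

Of the compounds shown here, three sharing one core have been tested in a functional assay on HepG2 cells (Homo sapiens) for inhibition, read by MTT assay, with a stated time of 48 h; a higher number here means a weaker inhibitor, a lower number a stronger inhibitor. Compound 1 `O=C(CSc1nnc(-c2ccncc2)n1-c1ccccc1)N/N=C/c1ccccc1` gives 18600 nM. Compound 2 `COc1ccc(/C=N/NC(=O)CSc2nnc(-c3ccncc3)n2-c2ccccc2)cc1` gives 27100 nM. Compound 3 `O=C(CSc1nnc(-c2ccncc2)n1-c1ccccc1)N/N=C/c1ccc([N+](=O)[O-])cc1` gives 15900 nM, the lowest of the three numbers, although a 1.2-fold lower number from compound 1 to compound 3 (0.07 log units; within the scatter) and a 1.7-fold lower number from compound 2 to compound 3 (0.23 log units; within the scatter) both lie within the scatter, as does a 1.5-fold higher number from compound 1 to compound 2 (0.16 log units; within the scatter).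

Compound 4 `O=C(CSc1nnc(-c2ccncc2)n1-c1ccccc1)N/N=C/c1ccc(O)cc1` differs from compound 3 in one place: hydroxy in place of nitro on an aromatic carbon. Among the measured compounds shown here, the steps that bear on this are those touching the same aromatic carbon, from hydrogen to nitro, from methoxy to nitro and from hydrogen to methoxy, and none of them moved this assay beyond the scatter. Nothing among the three measured compounds suggests that a hydroxy group would behave differently, so no step beyond the scatter is expected in this assay.

Compound 4 is therefore estimated at 20000 nM, with a range from 9000 nM to 45000 nM, which corresponds to an expected step of a 1.3-fold higher number from compound 3 to compound 4 (0.10 log units; within the scatter).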

Compound 4, half-maximal inhibitory concentration: > 50000 nM
Compound 4 was reported as a limit (the forecaster's own chance of this, stated with the estimate: 5%); at least 2.5-fold (0.39 log units) between middle value and limit.
By their numbers in this assay, from the lowest: compounds 3, 1 and 2 (each within the scatter of the next). At a limit, above all of these: compound 4.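

In this assay, compound 4 is a limit and not a number: the limit of > 50000 nM in this assay, at which 1 of the 4 values shown sits. At this aromatic carbon, para to a large group, hydroxy is the only group shown that gives steps beyond the scatter, with an at least 3.1-fold higher number from compound 3 to compound 4 (0.49 log units; beyond the scatter) and an at least 2.6-fold higher number from compound 1 to compound 4 (0.42 log units; beyond the scatter), whereas hydrogen, methoxy and nitro all stayed within the scatter of one another. The step that takes the methyl off the oxygen, an at least 1.8-fold higher number from compound 2 to compound 4 (0.26 log units; that floor lies within the scatter), has a floor within the scatter, so this comparison stays undecided.

As far as these compounds go, how far compound 4 really lies beyond its limit remains open. Also open, from the compounds shown here alone, is whether an amine or a carboxylic acid on this carbon would follow hydroxy or stay with the other three groups.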